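Swapping chlorophenyl for methoxyphenyl on a cyanoguanidine chain

The compounds below may be only part of what the source reports. "The series", "measured", "known", "first", "only" and "open" are said of these compounds alone.

Compound 1, `CC1(C)Oc2ccc(C#N)cc2[C@@H](NC(=O)Nc2ccccn2)[C@@H]1O`, gives 440 nM in a functional assay (aorta) with Rattus norvegicus as the target; on this read-out lower numbers stand for stronger inhibition and higher numbers for weaker inhibition.
Compound 2, `CC1(C)Oc2ccc(C#N)cc2[C@@H](n2cc(C#N)c3ccccc32)[C@@H]1O`, gives 2200 nM in this assay.
Compound 3, `CC1(C)Oc2ccc(C#N)cc2[C@@H](/N=C(\NC#N)Nc2cccc(Cl)c2)[C@@H]1O`, gives 600 nM in this assay.

All three share the same core and differ only in the side chain attached to it. The number for compound 3 sits close to that of compound 1, a gap that lies within the usual scatter of repeated measurements, so the two cannot be told apart on these data. Against compound 2 the number for compound 3 is clearly lower, a gap beyond the scatter, which means compound 3 inhibits more strongly than compound 2.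

Compound 4, `COc1ccc(N/C(=N/[C@@H]2c3cc(C#N)ccc3OC(C)(C)[C@H]2O)NC#N)cc1`, has not yet been measured. It differs from compound 3 in one place: 4-methoxyphenyl in place of 3-chlorophenyl on an amine nitrogen. Among the measured compounds shown here, no pair of measured compounds differs by a swap of this kind, so there is no measured step to lean on. In this assay the expected step is a 1.5-fold higher number from compound 3 to compound 4 (0.18 log units; within the scatter), leaning toward a somewhat higher number but not clearly beyond the scatter. For compound 4 the expected value is 900 nM, with a likely range from 300 nM to 3000 nM.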

Compound 4, half-maximal inhibitory concentration: 32500 nM
Beside the measured number, compound 4's estimate is 36-fold (1.56 log units) below it; the measured number lies above the stated range.
By their numbers in this assay, from the lowest: compounds 1 and 3 (each within the scatter of the next); then compound 2; then compound 4.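

The aryl group on this amine nitrogen matters a great deal in this assay: 4-methoxyphenyl in place of 3-chlorophenyl gives a 54-fold higher number from compound 3 to compound 4 (1.73 log units; beyond the scatter), a step far beyond the scatter. The earlier compounds shown here differ from one another in the whole side chain, so they could not show how much depends on this ring alone; here the shared core and the cyanoguanidine chain stay the same, and inhibition still weakens sharply. No measurement shown here accounts for the size of this loss.

This swap changes two things at once, the substituent on the ring and its place on the ring, so the two compounds cannot show which change carries the loss; 3-methoxyphenyl and 4-chlorophenyl would pull the two apart. On these data alone, it also remains open whether an unsubstituted phenyl ring would keep inhibition near that of compound 3 or fall toward that of compound 4, which would show whether the chlorine helps or the methoxy group hurts.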